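The source may hold more compounds than are shown below. What is called first, only, known or untested is meant among the compounds shown, and "the series" means these compounds.

Values in an ADME assay on Vero cells (Chlorocebus sabaeus) for cytotoxicity, with a stated time of 5 days (on this read-out higher numbers stand for weaker inhibition and lower numbers for stronger inhibition), each of them a limit of the assay and not a number:

- compound 1 `COc1nc(NC2CC2)c2ncn([C@H]3C[C@H](N=[N+]=[N-])[C@@H](CO)O3)c2n1`: > 100000 nM
- compound 2 `[N-]=[N+]=N[C@H]1C[C@H](n2cnc3c(NC4CC4)nc(Cl)nc32)O[C@@H]1CO`: > 100000 nM
- compound 3 `[N-]=[N+]=N[C@H]1C[C@H](n2cnc3c(NC4CC4)nc(N)nc32)O[C@@H]1CO`: > 100000 nM

Compound 2 gives > 100000 nM, which is a limit. It therefore has no exact place on this scale, and the two other measured compounds offer only limits for comparison.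

The next compound to be tested is compound 4 `COc1nc(Cl)nc2c1ncn2[C@H]1C[C@H](N=[N+]=[N-])[C@@H](CO)O1`. It has methoxy in place of cyclopropylamino on an aromatic carbon, while the chloro group stays: methoxy in place of cyclopropylamino on an aromatic carbon.

Three measured steps can be consulted: a step that the two limits leave unreadable from compound 1 to compound 2, a step that the two limits leave unreadable from compound 1 to compound 3 and a step that the two limits leave unreadable from compound 2 to compound 3. None has a readable size, and all three leave the cyclopropylamino group untouched. They show that swapping methoxy, chloro and amino never brought a measurable number, but they do not test the change made here. The firmest observation is the limit of > 100000 nM in this assay, at which 3 of the 3 values shown sit.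

With no readable step to draw on, no change beyond the usual scatter is expected in this assay, and another limit is the likeliest report. The expected step is a number no higher from compound 2 to compound 4 (the limit leaves the size open). For compound 4 the estimated value is 100000 nM, with an expected range from 30000 nM to 200000 nM.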

Compound 4, half-maximal inhibitory concentration: > 100000 nM
Compound 4: no number, only a limit; the forecaster's own chance of this, stated with the estimate: 85%; the middle value lies on the limit itself.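

In this assay compound 4 gives > 100000 nM, which is a limit of the assay and not a number. Within the data shown here, compound 2 also carries only a limit, so no step between compound 2 and compound 4 can be read. The compounds shown leave open whether methoxy in place of cyclopropylamino changes this read-out at all, because all the values share one ceiling: the limit of > 100000 nM in this assay, at which 4 of the 4 values shown sit.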